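This account rests on a few compounds, and the source may have more. Where it says the series, first, only, none or still open, it means among the compounds named here.

Measured so far:
Compound 1, `Cc1cc(N2CCCC2)c(S(C)(=O)=O)cc1C(=O)N=C(N)N` — in a functional assay for inhibition of sodium/hydrogen exchanger (Oryctolagus cuniculus) (on this read-out lower numbers stand for stronger inhibition and higher numbers for weaker inhibition), compound 1 gives 11 nM.
Compound 2, `Cc1cc(N2CCCC(O)C2)c(S(C)(=O)=O)cc1C(=O)N=C(N)N` — in this assay compound 2 gives 30 nM.

Within the data shown here, compound 2 stands at the higher of the two numbers: the single measured step, a 2.7-fold higher number from compound 1 to compound 2 (0.44 log units; beyond the scatter), separates it from compound 1. Compound 3, `Cc1cc(N2CCC(N)CC2)c(S(C)(=O)=O)cc1C(=O)N=C(N)N`, is not yet measured. It differs from compound 2 by 4-aminopiperidin-1-yl in place of 3-hydroxypiperidin-1-yl on an aromatic carbon. Among the measured compounds shown here, no measured step pairs these two substituents; the only step on record, from compound 1 to compound 2, exchanges a pyrrolidine for a hydroxylated piperidine and so speaks only indirectly to swapping one substituted piperidine for another of the same size and the same count of donors and acceptors. With nothing more to lean on, any step in this assay from compound 2 to compound 3 is expected to stay within the scatter, no change at the digits printed from compound 2 to compound 3 (within the scatter). Compound 3 is therefore estimated at 30 nM, with a range from 10 nM to 90 nM.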

Compound 3, half-maximal inhibitory concentration: 9.8 nM
Compound 3: middle estimate off by 3.1-fold (0.49 log units), on the high side; measured number below the stated range.
By their numbers in this assay, from the lowest: compounds 3 and 1 (each within the scatter of the next); then compound 2.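

In this assay the substituent on this aromatic carbon is shown to matter beyond ring size and the counted donors and acceptors, since 4-aminopiperidin-1-yl and 3-hydroxypiperidin-1-yl match in these yet their exchange gives a 3.1-fold lower number from compound 2 to compound 3 (0.49 log units; beyond the scatter) in this series. A six-membered ring can also read level with the pyrrolidine, with a 1.1-fold lower number from compound 1 to compound 3 (0.05 log units; within the scatter) when 4-aminopiperidin-1-yl enters, so ring size alone does not account for the step from compound 1 to compound 2. No evidence is available to explain the difference between the two piperidines.

The compounds shown do not separate the change from hydroxyl to amine from the change in its numbered place on the piperidine, which 4-hydroxypiperidin-1-yl and 3-aminopiperidin-1-yl would do. Also open, going by these compounds, is how a carboxylic acid or a longer aminoalkyl chain on the piperidine would read.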